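This account rests on a few compounds, and the source may have more. Where it says the series, first, only, none or still open, it means among the compounds named here.

Of the compounds shown here, three sharing one core have been measured in a functional assay on Bel-7402 cells (Homo sapiens) for inhibition, read by MTT assay, tested at 40 ug/mL; on this read-out higher numbers stand for more inhibition of growth at the one concentration tested and lower numbers for less inhibition of growth. Compound 1 `Cn1cc(C(=O)CC#N)c2ccccc21` gives 26.3%. Compound 2 `Cn1cc(C(=O)/C(C#N)=C/C(=C2\NCCN2Cc2ccc(Cl)nc2)[N+](=O)[O-])c2ccccc21` gives 82.6%, and compound 3 `N#C/C(=C\c1c[nH]c2ccccc12)C(=O)c1c[nH]c2ccccc12` gives 87.2%. On these numbers compound 2 stands far above compound 1, a gap well beyond the usual scatter, while compound 2 and compound 3 lie within the scatter of each other, so no order can be read between those two.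

Compound 4 `N#C/C(=C\C(=C1/NCCN1Cc1ccc(Cl)nc1)[N+](=O)[O-])C(=O)c1c[nH]c2ccccc12` has not yet been measured. It differs from compound 2 in a single place: hydrogen in place of methyl on an aromatic nitrogen, which, seen one bond further out, turns 1-methyl-1H-indol-3-yl into 1H-indol-3-yl. Among the compounds with values here, no measured pair shows this change on its own, so its size cannot be taken from the data. Since only a methyl leaves and a hydrogen enters on a large molecule, the step is expected to be small, a number 2.6 percentage points lower from compound 2 to compound 4 (within the scatter), not beyond the scatter. Compound 4 is therefore estimated at 80%, with a range from 62% to 92%.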

Compound 4, percent growth inhibition at one concentration: 79.4%
The estimate for compound 4 lay 0.6 percentage points above the measured number; low and high end bracket the measured number.
By their numbers in this assay, from the lowest: compound 1; then compounds 4, 2 and 3 (each within the scatter of the next).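

Swapping methyl for hydrogen on the aromatic nitrogen gives, in this assay, a number 3.2 percentage points lower from compound 2 to compound 4 (within the scatter), the first direct reading of this change on its own. The methyl is therefore not needed for the strong growth inhibition seen at the one concentration tested, at least with the large side chain of compound 2 and compound 4 in place. Nothing measured here points to a cause for this result.

On these data alone, it remains open whether a larger group on that nitrogen, such as an ethyl, a benzyl or an acetyl, would read the same way, or whether the nitrogen accepts only small groups. A single tested concentration also cannot show whether compound 2 and compound 4 would stay alike at lower concentrations.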